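Isopropoxy in place of fluoro on a fused ring

The compounds below may be only part of what the source reports. "The series", "measured", "known", "first", "only" and "open" are said of these compounds alone.

Compound 1, `Nc1nccc(-c2ccc3nc(C4COc5ccc(F)cc5C4)oc3c2)n1`: 15 nM
Compound 2, `Nc1nccc(-c2ccc3nc(C4COc5ccc(F)cc5C4)[nH]c3c2)n1`: 6 nM

Both compounds were tested in an assay on isolated protein for inhibition of Rho-associated protein kinase 2 (Homo sapiens); on this read-out higher numbers stand for weaker inhibition and lower numbers for stronger inhibition. Compound 2 holds the lower of the two numbers, and compound 1 stands at a higher value, a gap that lies beyond the usual scatter of repeated measurements. Compound 2 is therefore the starting point for the next step.

Compound 3, `CC(C)Oc1ccc2c(c1)CC(c1nc3ccc(-c4ccnc(N)n4)cc3[nH]1)CO2`, keeps the whole of compound 2 except at one place: isopropoxy in place of fluoro on an aromatic carbon. The fluoro leaves and an isopropoxy enters, on an aromatic carbon of the six-membered aromatic ring of carbon only, meta to a fused ring and para to a fused ring.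

Going by the values given here, no pair of measured compounds shows what such an exchange does in this assay, so there is no step to lean on. The isopropoxy brings one hydrogen-bond acceptor and three more heavy atoms than the fluoro it replaces; without a precedent, a modest move is expected. The step from compound 2 to compound 3 is expected to be a 1.7-fold higher number from compound 2 to compound 3 (0.22 log units; within the scatter), at most a small shift toward a higher number and possibly none beyond the scatter. Compound 3 is estimated at 10 nM, with a range from 3 nM to 40 nM.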

Compound 3, half-maximal inhibitory concentration: 296 nM
Beside the measured number, compound 3's estimate is 30-fold (1.47 log units) below it; the measured number lies above the stated range.
By their numbers in this assay, from the lowest: compound 2; then compound 1; then compound 3.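

Isopropoxy in place of fluoro gives a 49-fold higher number from compound 2 to compound 3 (1.69 log units; beyond the scatter) in this assay and so shows that this aromatic carbon, meta to a fused ring and para to a fused ring, does not tolerate every group. Going by these compounds alone, compound 1 and compound 2 both carry the fluoro and could say nothing about this place; the new step is the first reading of it, and it links a group of more heavy atoms, with a hydrogen-bond acceptor that fluoro lacks, to much weaker inhibition. The measurements at hand do not explain the size of this step, and a single exchange cannot separate the added heavy atoms from the added acceptor or from the loss of the fluoro.

The compounds shown leave open how the number changes with smaller groups at this place, such as a hydrogen, a chlorine, a hydroxyl or a methoxy, and therefore whether the sharp rise belongs to any oxygen-linked group or only to the branched isopropoxy. They also leave open whether isopropoxy on the core of compound 1 would give a step of similar size.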